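Amide substituent variation on the shared core: compound 4

A few compounds are considered here, and "the series" means these few. Any claim that something is new, unique, unknown or untested is made for them only; others in the source may bear on it.

Measured compounds in a functional assay on PC-3 cells (Homo sapiens) for antiproliferative activity, read by MTT assay, with a stated time of 72 h; on this read-out lower numbers stand for stronger inhibition and higher numbers for weaker inhibition:
- compound 1 `C=C(C)C(=O)Nc1cc2c(N3CCc4ccccc43)ncnc2cc1OC` gives 4830 nM
- compound 2 `COc1cc2ncnc(N3CCc4ccccc43)c2cc1NC(=O)/C=C/C(C)C` gives 6530 nM
- compound 3 `COc1cc2ncnc(N3CCc4ccccc43)c2cc1NC(=O)/C=C/CN(C)C` gives 2190 nM

Compound 3 stands lowest of the three measured numbers in this assay. Its nearest neighbour is compound 1, which lies higher by a 2.2-fold lower number from compound 1 to compound 3 (0.34 log units; beyond the scatter) read backwards; the furthest is compound 2, with the step of a 3.0-fold lower number from compound 2 to compound 3 (0.47 log units; beyond the scatter) separating them. Both steps are beyond the scatter, so compound 3 is the strongest inhibitor of the three.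

Compound 4 `CCN(CC)C/C=C/C(=O)Nc1cc2c(N3CCc4ccccc43)ncnc2cc1OC` differs from compound 3 only in the amine on the acrylamide chain: diethylamino in place of dimethylamino on a saturated chain carbon bound to a double-bonded chain carbon.

Going by the values given here, none of the measured steps changes the size of this amine. The steps of a 2.2-fold lower number from compound 1 to compound 3 (0.34 log units; beyond the scatter) and a 3.0-fold lower number from compound 2 to compound 3 (0.47 log units; beyond the scatter) concern bringing the dimethylaminomethyl group in at all, in place of a methyl on the carbonyl-bound carbon or an isopropyl on the chain carbon, and each was modest. Among the compounds with values here, exchanging the two methyls on the nitrogen for two ethyls is a smaller change than either of those, and the data give no step that speaks to its direction. The expectation for compound 4 in this assay is therefore a step of a 1.0-fold lower number from compound 3 to compound 4 (0.02 log units; within the scatter), which is within the scatter.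

Compound 4 is estimated at 2100 nM, with a range from 900 nM to 4800 nM.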

Compound 4, half-maximal inhibitory concentration: 3690 nM
Compound 4: the middle estimate sits 1.8-fold (0.24 log units) below what was measured; low and high end bracket the measured number.
By their numbers in this assay, from the lowest: compounds 3, 4, 1 and 2 (each within the scatter of the next, the first and the last beyond it).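

In this assay the exchange of dimethylamino for diethylamino on a saturated chain carbon bound to a double-bonded chain carbon gives a step within the scatter (a 1.7-fold higher number from compound 3 to compound 4 (0.23 log units; within the scatter)), so this position accepts the larger of the two amines without a readable loss. The separation from the amine-free side chains does not carry over to the diethylamino group: the steps to compound 3 were beyond the scatter (a 3.0-fold lower number from compound 2 to compound 3 (0.47 log units; beyond the scatter) and a 2.2-fold lower number from compound 1 to compound 3 (0.34 log units; beyond the scatter)), while those to compound 4 are within it (a 1.8-fold lower number from compound 2 to compound 4 (0.25 log units; within the scatter) and a 1.3-fold lower number from compound 1 to compound 4 (0.12 log units; within the scatter)). The advantage of compound 3 over compounds 1 and 2 therefore cannot yet be read as a feature of dialkylamino groups in general, since compound 4 lies within the scatter of all three.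

From the compounds shown here alone, whether a cyclic amine such as pyrrolidine, piperidine or morpholine on the same chain carbon, or a longer chain between the amine and the double bond, would separate from compounds 1 and 2 remains open. No evidence at hand bears on what lies behind these numbers.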